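The source may report more compounds than this note shows. Statements on the series, on what has been measured and on what is new or still open speak of the compounds shown alone.

Within the data shown here, compound 3 `CNC(=O)c1cc(Oc2ccc(NC(=O)c3cc(-c4ccc(C)cc4)ncn3)cc2F)ccn1` gives 13200 nM in a functional assay on A549 cells (Homo sapiens) for cytotoxicity, read by MTT assay, with a stated time of 72 h (a lower number here means a stronger inhibitor, a higher number a weaker inhibitor), the lowest of the two numbers measured so far; the nearest neighbour is compound 2 `CNC(=O)c1cc(Oc2ccc(NC(=O)c3cc(-c4ccccc4)ncn3)cc2)ccn1`, which carries a phenyl in place of the 4-methylphenyl and no fluoro on the shared core, and which gives 27100 nM, a gap beyond the scatter. Compound 1 `CNC(=O)c1cc(Oc2ccc(NC(=O)c3cc(-c4ccc(F)cc4)ncn3)cc2F)ccn1` returns only a limit of the assay, > 100000 nM, as recorded in the limit of > 100000 nM in this assay, at which 1 of the 3 values shown sits. Among the measured compounds shown here, the single measured step, an at least 7.5-fold lower number from compound 1 to compound 3 (0.87 log units; beyond the scatter), shows that the group at this aromatic carbon moves the number by a fair margin, with methyl the better of the two. Compound 4 `CNC(=O)c1cc(Oc2ccc(NC(=O)c3cc(-c4ccccc4)ncn3)cc2F)ccn1` is the next member: hydrogen in place of methyl on an aromatic carbon. For the measured compounds named here, no measured step removes the methyl itself, so the expectation rests on the fluoro-to-methyl step alone, which points toward methyl helping; a small to modest rise in the number is therefore expected, a 1.9-fold higher number from compound 3 to compound 4 (0.28 log units; within the scatter). Compound 4 is estimated to give 25000 nM, with a range from 9000 nM to 70000 nM.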

Compound 4, half-maximal inhibitory concentration: 23200 nM
Beside the measured number, compound 4's estimate is 1.1-fold (0.03 log units) above it, and the stated range covers the measured number.
By their numbers in this assay, from the lowest: compounds 3, 4 and 2 (each within the scatter of the next, the first and the last beyond it). At a limit, above all of these: compound 1.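

In this assay, the methyl at this carbon cannot be told apart from hydrogen, with a 1.8-fold higher number from compound 3 to compound 4 (0.24 log units; within the scatter). The fluoro on the shared core likewise makes no difference beyond the scatter, with a 1.2-fold lower number from compound 2 to compound 4 (0.07 log units; within the scatter). The fluoro at the carbon para to a large group is what stands apart, with an at least 4.3-fold lower number from compound 1 to compound 4 (0.63 log units; beyond the scatter), so the earlier fluoro-to-methyl step says more about fluoro than about any gain from methyl, and the starting value of this step is a limit of the assay and not a number: the limit of > 100000 nM in this assay, at which 1 of the 4 values shown sits.

The compounds shown leave open whether chloro, methoxy or an amine at this carbon would part from hydrogen and methyl. They also leave open whether the 4-fluorophenyl group gives the same result on a core without the fluoro.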